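Aryl swap on the ethenyl arm: compound 2 toward compound 3

The source may report more compounds than this note shows. Statements on the series, on what has been measured and on what is new or still open speak of the compounds shown alone.

Two members of the series are measured in an assay on cells for inhibition of Ectonucleotide pyrophosphatase/phosphodiesterase family member 1 (Homo sapiens), with a stated time of 60 min; a lower number here means a stronger inhibitor, a higher number a weaker inhibitor. Compound 1 `COc1cc2nc(/C=C/c3ccccc3)nc(N3CCC(CCNS(N)(=O)=O)CC3)c2cc1OC` gives 1840 nM. Compound 2 `COc1cc2nc(/C=C/c3ccncc3)nc(N3CCC(CCNS(N)(=O)=O)CC3)c2cc1OC` gives 218 nM, and it stands as the lowest of the two numbers, with compound 1 as its nearest neighbour. Going by the values given here, the one measured step, an 8.4-fold lower number from compound 1 to compound 2 (0.93 log units; beyond the scatter), is beyond the scatter.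

Compound 3 `COc1cc2nc(/C=C/c3ccccc3F)nc(N3CCC(CCNS(N)(=O)=O)CC3)c2cc1OC` has not been measured in this assay. It differs from compound 2 in one place: 2-fluorophenyl in place of pyridin-4-yl on a double-bonded chain carbon bound to a double-bonded chain carbon. Among the compounds with values here, the change returns the ring of carbon only that compound 1 carries, now bearing a fluorine, and removes the ring nitrogen that compound 2 carries. The only step that bears on this is the one from compound 1 to compound 2, which moved the number markedly in the opposite direction; the effect of adding fluorine to that ring is not shown by any measured pair. For compound 3 the expectation is therefore a higher number than compound 2, around the size of that step reversed, a 5.5-fold higher number from compound 2 to compound 3 (0.74 log units; beyond the scatter), leaning toward compound 1 because of 1840 nM. The estimate for compound 3 is 1200 nM, within 400 nM to 4000 nM.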

Compound 3, inhibition constant: 211 nM
Estimate against measurement, compound 3: 5.7-fold (0.75 log units) above, and the stated range ends above it.
By their numbers in this assay, from the lowest: compounds 3 and 2 (each within the scatter of the next); then compound 1.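

In this assay, a ring nitrogen is not needed on the ethenyl arm for a number at this level: the change gives a 1.0-fold lower number from compound 2 to compound 3 (0.01 log units; within the scatter) even though 2-fluorophenyl carries no hydrogen-bond acceptor and pyridin-4-yl carries one. A single substituent on the phenyl ring of compound 1 is enough to reach the same level, since fluoro in place of hydrogen on an aromatic carbon gives an 8.7-fold lower number from compound 1 to compound 3 (0.94 log units; beyond the scatter) and leaves the ring of carbon only in place. Two different changes to compound 1 therefore arrive at numbers within the scatter of each other, and nothing measured here explains why, as no supporting measurement bears on this result.

From the compounds shown here alone, it remains open whether the gain is specific to fluoro or would also appear with chloro or methoxy in its place on the phenyl ring. Also open, going by these compounds, is whether a fluoro on the pyridin-4-yl ring of compound 2 would lower the number further or add nothing to what the ring nitrogen already gives.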